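The source may hold more compounds than are shown below. What is called first, only, known or untested is meant among the compounds shown, and "the series" means these compounds.

Measured in a functional assay on K562 cells (Homo sapiens) for antiproliferative activity, with a stated time of 72 h; on this read-out lower numbers stand for stronger inhibition and higher numbers for weaker inhibition:

Compound 1 `OC[C@H]1O[C@@H](n2cnc3c(NCc4ccccc4F)ncnc32)[C@H](O)[C@@H]1O`: 33200 nM
Compound 2 `OC[C@H]1O[C@@H](n2cnc3c(NCc4ccc(Cl)cc4)ncnc32)[C@H](O)[C@@H]1O`: 218000 nM
Compound 3 `Cc1cccc(CNc2ncnc3c2ncn3[C@@H]2O[C@H](CO)[C@@H](O)[C@H]2O)c1`: > 166000 nM, a limit

Compound 3 stands at the limit of > 166000 nM in this assay, at which 1 of the 3 values shown sits, so it has a limit and no number. Compound 4 `Cc1ccc(CNc2ncnc3c2ncn3[C@@H]2O[C@H](CO)[C@@H](O)[C@H]2O)cc1` differs from compound 3 in one place: 4-methylphenyl in place of 3-methylphenyl on a saturated chain carbon bound to a nitrogen on an aromatic ring. Here 4-methylphenyl takes the place of 3-methylphenyl on a saturated chain carbon bound to a nitrogen on an aromatic ring.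

Among the measured compounds shown here, no measured step makes this exact change, but two bear on it indirectly. Replacing 2-fluorophenyl with 4-chlorophenyl gives a 6.6-fold higher number from compound 1 to compound 2 (0.82 log units; beyond the scatter). Replacing 2-fluorophenyl with 3-methylphenyl gives an at least 5.0-fold higher number from compound 1 to compound 3 (0.69 log units; beyond the scatter). Both go towards higher numbers, and both lie beyond the scatter. The remaining comparison is a step that the limit leaves unreadable from compound 2 to compound 3, so it offers no guidance on direction.

Compound 4 is therefore expected to remain among the high numbers in this assay, near compound 2 with its 218000 nM, and not to approach compound 1 with its 33200 nM. No step beyond the scatter is expected, and the estimated change is a step that the limit leaves unreadable from compound 3 to compound 4. For compound 4 the estimated value is 170000 nM, with an expected range from 70000 nM to 400000 nM.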

Compound 4, half-maximal inhibitory concentration: > 166000 nM
Compound 4: no number, only a limit; the forecaster's own chance of this, stated with the estimate: 45%; the middle value lies beyond the limit too.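

In this assay compound 4 gives > 166000 nM, which is a limit and not a number, so 4-methylphenyl in place of 3-methylphenyl brings no readable gain on this read-out. Its one readable step, 4-methylphenyl in place of 2-fluorophenyl, is an at least 5.0-fold higher number from compound 1 to compound 4 (0.69 log units; beyond the scatter), in the same direction as the steps to 4-chlorophenyl and 3-methylphenyl, and no listed compound goes against this: all three stand on the high side of compound 1. The steps from compound 2 and from compound 3 to compound 4 cannot be read, so any order among these three stays unknown, and compound 3 and compound 4 now share the same limit: the limit of > 166000 nM in this assay, at which 2 of the 4 values shown sit.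

The compounds shown leave open whether the better value of compound 1 belongs to the fluorine or to the 2-substituted phenyl, which 2-methylphenyl or 2-chlorophenyl on the same saturated chain carbon would separate. They also leave open whether a carboxylic acid or an amine on the phenyl ring, or a longer chain in place of the single saturated carbon, would bring a number well under the limit.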